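Replacing 4-Methylphenyl with (Pyridin-3-yl)methyl on the Ring Nitrogen

The source may report more compounds than this note shows. Statements on the series, on what has been measured and on what is new or still open speak of the compounds shown alone.

Compound 1, `COc1ccc(N2CCN(C(=S)SCc3ccc(C(=O)Nc4ccccc4N)cc3)CC2)cc1`, gives 35.9% in a functional assay on A-375 cells (Homo sapiens) for antiproliferative activity, read by CCK-8 assay, with a stated time of 72 h, tested at 8 uM; a higher number here means a stronger effect of the compound at the concentration tested, a lower number a weaker effect.
Compound 2, `N#Cc1ccc(N2CCN(C(=S)SCc3ccc(C(=O)Nc4ccccc4N)cc3)CC2)cc1`, gives 62.9%.
Compound 3, `Cc1ccc(N2CCN(C(=S)SCc3ccc(C(=O)Nc4ccccc4N)cc3)CC2)cc1`, gives 26.4%.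

Compound 3 has the smallest number of the three, though one of its gaps lies within the scatter (a number 9.5 percentage points lower from compound 1 to compound 3 (within the scatter)), while the other is large (a number 36.5 percentage points lower from compound 2 to compound 3 (beyond the scatter)). Compound 4, `Nc1ccccc1NC(=O)c1ccc(CSC(=S)N2CCN(Cc3cccnc3)CC2)cc1`, differs from compound 3 by (pyridin-3-yl)methyl in place of 4-methylphenyl on an amine nitrogen in a ring. The measured steps (a number 27 percentage points higher from compound 1 to compound 2 (beyond the scatter), a number 36.5 percentage points lower from compound 2 to compound 3 (beyond the scatter)) only swap a small group on that aromatic ring; none removes the ring itself or adds a ring with a hetero atom, so they bear only loosely here. No direction is expected with confidence, so compound 4 is estimated at 35%, with a range of 15% to 60%, an expected step of a number 8.6 percentage points higher from compound 3 to compound 4 (within the scatter).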

Compound 4, a percentage reported as inhibition, at one concentration (the size of the read-out at that concentration, not a potency): 89.2%
Estimate against measurement, compound 4: 54.2 percentage points below; the measured number lies above the stated range.
By their numbers in this assay, from the lowest: compounds 3 and 1 (each within the scatter of the next); then compound 2; then compound 4.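

On the ring nitrogen, the whole aromatic group can be exchanged, not only a small group on it: in this assay, (pyridin-3-yl)methyl gives a number 62.8 percentage points higher from compound 3 to compound 4 (beyond the scatter), a number 53.3 percentage points higher from compound 1 to compound 4 (beyond the scatter) and a number 26.3 percentage points higher from compound 2 to compound 4 (beyond the scatter). All three steps are beyond the scatter, so none of the small swaps on the 4-substituted phenyl ring matched this change. No measurement here accounts for the gain.

This change adds both a ring nitrogen and a carbon link, so their contributions remain unseparated. Benzyl or directly attached pyridin-3-yl would help tell them apart.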